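This account rests on a few compounds, and the source may have more. Where it says the series, first, only, none or still open, it means among the compounds named here.

Measured compounds in a functional assay on CCRF-CEM cells (Homo sapiens) for cytotoxicity; on this read-out lower numbers stand for stronger inhibition and higher numbers for weaker inhibition:
compound 1 `O=C(/C=C/C(=O)N1C/C(=C\c2ccc([N+](=O)[O-])cc2)C(=O)/C(=C/c2ccc([N+](=O)[O-])cc2)C1)Nc1ccc([N+](=O)[O-])cc1` gives 410 nM
compound 2 `O=C(/C=C/C(=O)N1C/C(=C\c2ccc([N+](=O)[O-])cc2)C(=O)/C(=C/c2ccc([N+](=O)[O-])cc2)C1)Nc1ccc(Cl)cc1` gives 810 nM
compound 3 `Cc1ccc(NC(=O)/C=C/C(=O)N2C/C(=C\c3ccccc3)C(=O)/C(=C/c3ccccc3)C2)cc1C` gives 7100 nM

Compound 2 stands second highest of these three numbers. Its nearest neighbour is compound 1, which lies within the scatter of it; its furthest is compound 3, which lies beyond the scatter, though compound 3 differs from compound 2 in more than one place, so the two values only show the gap and nothing about a single change.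

Compound 4 `Cc1ccc(NC(=O)/C=C/C(=O)N2C/C(=C\c3ccc([N+](=O)[O-])cc3)C(=O)/C(=C/c3ccc([N+](=O)[O-])cc3)C2)cc1` has not yet been measured in this assay. It differs from compound 2 by methyl in place of chloro on an aromatic carbon. Going by the values given here, the one measured step at this same aromatic carbon is a 2.0-fold higher number from compound 1 to compound 2 (0.30 log units; within the scatter), a change that stayed within the scatter. Nothing measured here speaks to a methyl at that place, so the step from compound 2 to compound 4 is expected to be small, a 1.2-fold higher number from compound 2 to compound 4 (0.09 log units; within the scatter), with no clear direction. Compound 4 is therefore estimated at 1000 nM, with a range from 400 nM to 2500 nM.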

Compound 4, half-maximal inhibitory concentration: 890 nM
Compound 4: middle estimate off by 1.1-fold (0.05 log units), on the high side; the range from low to high includes it.
By their numbers in this assay, from the lowest: compounds 1, 2 and 4 (each within the scatter of the next, the first and the last beyond it); then compound 3.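

At this aromatic carbon, para to a large group, methyl in place of chloro gives a 1.1-fold higher number from compound 2 to compound 4 (0.04 log units; within the scatter) in this assay, so 4-chlorophenyl and 4-methylphenyl cannot be told apart on this read-out. Methyl in place of nitro gives a 2.2-fold higher number from compound 1 to compound 4 (0.34 log units; beyond the scatter) and is the first step at this place to pass the scatter, if only modestly, whereas chloro in place of nitro gave a 2.0-fold higher number from compound 1 to compound 2 (0.30 log units; within the scatter) and did not. Nothing available here accounts for these steps.

The compounds shown leave open what an amine or a carboxylic acid at this same carbon would do to the number. Compound 3 differs from the others in more than one place, so what the nitro groups on the rest of the molecule contribute also remains unresolved.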